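This account rests on a few compounds, and the source may have more. Where it says the series, first, only, none or still open, it means among the compounds named here.

Among the compounds with values here, in a functional assay on SK-BR-3 cells (Homo sapiens) for cytotoxicity, read by MTT assay, with a stated time of 72 h (on this read-out higher numbers stand for weaker inhibition and lower numbers for stronger inhibition), three compounds on one shared core have numbers so far: compound 1 (`Nc1ccc(Nc2c(C(=O)NCc3ccc(F)cc3)nc(Br)c3cccnc23)cc1`) gives 4000 nM, compound 2 (`N[C@H]1CC[C@H](Nc2c(C(=O)NCc3ccc(F)cc3)nc(Br)c3cccnc23)CC1`) gives 2000 nM and compound 3 (`O=C(NCc1ccc(F)cc1)c1nc(Br)c2cccnc2c1N1CCNCC1`) gives 6000 nM. The place of compound 3 at the high end of these numbers is clear on one side only: there is a 3.0-fold higher number from compound 2 to compound 3 (0.48 log units; beyond the scatter), but also a 1.5-fold higher number from compound 1 to compound 3 (0.18 log units; within the scatter). The remaining step, a 2.0-fold lower number from compound 1 to compound 2 (0.30 log units; within the scatter), separates nothing.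

Next is compound 4 (`CNCCCNc1c(C(=O)NCc2ccc(F)cc2)nc(Br)c2cccnc12`), with this difference: (3-(methylamino)propyl)amino in place of piperazin-1-yl on an aromatic carbon. In words, (3-(methylamino)propyl)amino stands in place of piperazin-1-yl on an aromatic carbon. Within the data shown here, no measured step makes this exact exchange, and no measured compound carries an open chain here. The closest guides are the two steps into compound 3, read in reverse, since compound 1 and compound 2 also carry a substituted amino group rather than piperazin-1-yl. Among the measured compounds shown here, of these, only the step from compound 2 goes beyond the scatter, so the guide is weak. A modest move to a lower number in this assay is expected, no larger than a 3.0-fold higher number from compound 2 to compound 3 (0.48 log units; beyond the scatter) and possibly lost in the scatter. The expected step is a 2.4-fold lower number from compound 3 to compound 4 (0.38 log units; beyond the scatter). For compound 4 the estimated value is 2500 nM, with an expected range of 1000 nM to 6000 nM.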

Compound 4, half-maximal inhibitory concentration: 1000 nM
Compound 4: middle estimate off by 2.5-fold (0.40 log units), on the high side; low and high end bracket the measured number.
By their numbers in this assay, from the lowest: compounds 4, 2, 1 and 3 (each within the scatter of the next, the first and the last beyond it).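

Within the data shown here, compound 4 is the first open chain on this aromatic carbon, and it keeps the 6 heavy atoms of piperazin-1-yl, with the same 4 carbon and 2 nitrogen atoms, while losing the ring and gaining a hydrogen-bond donor; in this assay this exchange gives a 6.0-fold lower number from compound 3 to compound 4 (0.78 log units; beyond the scatter) as the step, so the arrangement of the same atom count matters here, not only their number. A ring on the amino nitrogen is not required either: replacing 4-aminophenyl with 3-(methylamino)propyl gives a 4.0-fold lower number from compound 1 to compound 4 (0.60 log units; beyond the scatter) as the step, whereas replacing 4-aminocyclohexyl with it gives a 2.0-fold lower number from compound 2 to compound 4 (0.30 log units; within the scatter) as the step, which leaves the open chain and the 4-aminocyclohexyl group unseparated. Nothing available explains why the open chain differs from piperazin-1-yl.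

As far as these compounds go, the role of the terminal methylamino group remains open, and a hydroxyl at the chain end or a plain propyl chain would address it. Also open, from the compounds shown here alone, is how far the distance between the two nitrogens counts, which a shorter ethyl linker or a longer butyl chain would test.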